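The source may hold more compounds than are shown below. What is called first, only, known or untested is meant among the compounds shown, and "the series" means these compounds.

The measured compounds:
compound 1, `O=S(=O)(c1cccc(-c2ccc3nccc(-c4ccncc4)c3n2)c1)N1CCC(O)CC1`, gives 5% in an ADME assay on microsomes from liver (Homo sapiens) for metabolic stability, read by LC-MS, using NADPH, with a stated time of 30 min, tested at 0.1 uM; a higher number here means that more of the compound is left, a lower number that less of the compound is left;
compound 2, `Nc1cccc(-c2ccc3nccc(-c4ccncc4)c3n2)c1`, gives 78% in this assay;
compound 3, `C[C@@H]1CN(S(=O)(=O)c2cccc(-c3ccc4nccc(-c5ccncc5)c4n3)c2)C[C@H](C)N1`, gives 34% in this assay.

Compound 3 stands second highest of the three: a number 29 percentage points higher from compound 1 to compound 3 (beyond the scatter), while a number 44 percentage points lower from compound 2 to compound 3 (beyond the scatter). Compound 4, `CS(=O)(=O)Nc1cccc(-c2ccc3nccc(-c4ccncc4)c3n2)c1`, differs from compound 3 in one place: methanesulfonamido in place of (3,5-dimethylpiperazin-1-yl)sulfonyl on an aromatic carbon. Going by the values given here, two measured steps bear on this change. Both sulfonyl-bearing compounds sit low, and the change from a sulfonyl group to a plain amino group on the same aromatic carbon was large, as a number 73 percentage points higher from compound 1 to compound 2 (beyond the scatter) shows. Compound 4 keeps a sulfonyl group but attached through a nitrogen, with a far smaller group overall, so it is expected to lie between compound 3 and compound 2. For compound 4 the estimated step is a number 21 percentage points higher from compound 3 to compound 4 (beyond the scatter), a modest rise beyond the scatter. Compound 4 is therefore expected to give about 55% in this assay, within a range from 30% to 80%.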

Compound 4, percent of the compound remaining in the Homo sapiens assay: 59%
Compound 4: the middle estimate sits 4 percentage points below what was measured, and the stated range covers the measured number.
By their numbers in the Homo sapiens assay, from the lowest: compound 1; then compound 3; then compound 4; then compound 2.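

In the Homo sapiens assay, methanesulfonamido on this aromatic carbon stands well clear of both sulfonyl-linked rings, with a number 25 percentage points higher from compound 3 to compound 4 (beyond the scatter) and a number 54 percentage points higher from compound 1 to compound 4 (beyond the scatter), while placing methylsulfonyl on the nitrogen of the amino group still gives a number 19 percentage points lower from compound 2 to compound 4 (beyond the scatter). Among these compounds, then, a sulfonyl group does not by itself go with a low number: compound 4 carries one and stands above compound 3 and compound 1, though below compound 2. The same change goes the other way in a physicochemical assay for solubility, read by HPLC, using the shake flask method, measured as kinetic solubility, with a stated time of 20 h, at pH 6.5, tested at 200 uM (a lower number here means a less soluble compound, a higher number a more soluble compound), where compound 3 gives 180000 nM and compound 4 gives 20000 nM.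

The compounds shown leave open whether an acetyl group on that nitrogen in place of methylsulfonyl, or a longer chain ending in an amine, would keep the number in the Homo sapiens assay near that of compound 4 without the drop in the physicochemical assay.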